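Swapping a Methoxy for Chlorine on the Pendant Ring

The source may report more compounds than this note shows. Statements on the series, on what has been measured and on what is new or still open speak of the compounds shown alone.

Compound 1, `COc1ccc(-c2nc3cccc(-c4cc(OC)c(OC)c(OC)c4)c3o2)cc1`, in a functional assay on A549 cells (Homo sapiens) for antiproliferative activity, read by MTT assay, with a stated time of 48 h (on this read-out higher numbers stand for weaker inhibition and lower numbers for stronger inhibition), gives 2200 nM.
Compound 2, `COc1cccc(-c2nc3cccc(-c4cc(OC)c(OC)c(OC)c4)c3o2)c1`, gives 3500 nM.
Compound 3, `COc1cc(-c2cccc3nc(-c4ccc(F)cc4)oc23)cc(OC)c1OC`, gives 8700 nM.

All three share one core and differ only in the aryl group attached to it. Compound 2 sits second highest of the three numbers: on one side the step is a 1.6-fold higher number from compound 1 to compound 2 (0.20 log units; within the scatter), while on the other side the step is a 2.5-fold higher number from compound 2 to compound 3 (0.40 log units; beyond the scatter).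

Compound 4, `COc1cc(-c2cccc3nc(-c4cccc(Cl)c4)oc23)cc(OC)c1OC`, has not been measured. Relative to compound 2 the change is chloro in place of methoxy on an aromatic carbon. Going by the values given here, no measured pair shows exactly this swap. The closest guide is the step of a 4.0-fold higher number from compound 1 to compound 3 (0.60 log units; beyond the scatter), where a halogen also replaced a methoxy on the pendant ring, and the step of a 2.5-fold higher number from compound 2 to compound 3 (0.40 log units; beyond the scatter), which points the same way. Both suggest that losing the methoxy for a halogen tends to raise the number, though only modestly, so for compound 4 a small rise in this assay is expected, a 1.4-fold higher number from compound 2 to compound 4 (0.15 log units; within the scatter), with a fair chance it stays within the scatter. The estimate for compound 4 is 5000 nM, expected to fall between 2000 nM and 14000 nM.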

Compound 4, half-maximal inhibitory concentration: > 25000 nM
Compound 4: no number, only a limit; the forecaster's own chance of this, stated with the estimate: 5%; middle value at least 5.0-fold (0.69 log units) from the limit.
By their numbers in this assay, from the lowest: compounds 1 and 2 (each within the scatter of the next); then compound 3. At a limit, above all of these: compound 4.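

The value for compound 4 is a limit of the assay and not a number: the limit of > 25000 nM in this assay, at which 1 of the 4 values shown sits. Even so, the step of an at least 7.1-fold higher number from compound 2 to compound 4 (0.85 log units; beyond the scatter) shows that chloro in place of methoxy, on an aromatic carbon meta to a large group, can cost far more than the modest halogen steps among the earlier compounds suggested. The step of an at least 2.8-fold higher number from compound 3 to compound 4 (0.45 log units; beyond the scatter) and the step of an at least 11-fold higher number from compound 1 to compound 4 (1.05 log units; beyond the scatter) set the 3-chlorophenyl compound apart from the 4-fluorophenyl, 3-methoxyphenyl and 4-methoxyphenyl compounds, so among these four, a halogen on the pendant ring does not have one fixed effect.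

On these data alone, how far the true number of compound 4 lies past the limit remains open. So does whether a fluoro, a hydroxyl or an amine at this same place would track compound 2 or compound 4.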